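Swapping the sulfonamide substituent in a thiourea series

The source may report more compounds than this note shows. Statements on the series, on what has been measured and on what is new or still open speak of the compounds shown alone.

In a functional assay on HepG2 cells (Homo sapiens) for antiproliferative activity, read by sulforhodamine B assay, with a stated time of 48 h (on this read-out higher numbers stand for weaker inhibition and lower numbers for stronger inhibition), compound 1 `NS(=O)(=O)c1ccc(N/C(S)=N\c2ccnc3cc(C(F)(F)F)ccc23)cc1` gives 52200 nM, and compound 2 `N=C(N)NS(=O)(=O)c1ccc(N/C(S)=N\c2ccnc3cc(C(F)(F)F)ccc23)cc1` gives 33500 nM, the lowest of the two numbers, though the step of a 1.6-fold lower number from compound 1 to compound 2 (0.19 log units; within the scatter) stays within the scatter. Compound 3 `Cc1cc(NS(=O)(=O)c2ccc(N/C(S)=N\c3ccnc4cc(C(F)(F)F)ccc34)cc2)on1` differs from compound 2 by a group of 6 heavy atoms (4 carbon, 1 nitrogen, 1 oxygen; one five-membered aromatic ring with 2 hetero atoms) in place of a group of 3 heavy atoms (1 carbon, 2 nitrogen; no ring), on a sulfonamide nitrogen. Among the measured compounds shown here, the only step that bears on this position, from compound 1 to compound 2, lay within the scatter, so compound 3 is expected to show a 1.0-fold lower number from compound 2 to compound 3 (0.02 log units; within the scatter), with no change beyond the scatter. Compound 3 is therefore estimated at 32000 nM, within a range from 10000 nM to 100000 nM.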

Compound 3, half-maximal inhibitory concentration: 28500 nM
Compound 3: middle estimate off by 1.1-fold (0.05 log units), on the high side, and the stated range covers the measured number.
By their numbers in this assay, from the lowest: compounds 3, 2 and 1 (each within the scatter of the next).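

On a sulfonamide nitrogen, this assay gives a 1.2-fold lower number from compound 2 to compound 3 (0.07 log units; within the scatter) when a five-membered aromatic ring replaces a group with no ring, so a ring at this position also stays within the scatter. Against hydrogen, 3-methyl-1,2-oxazol-5-yl gives a 1.8-fold lower number from compound 1 to compound 3 (0.26 log units; within the scatter) and likewise does not pass beyond the scatter. No supporting data bear on why these numbers sit so close together. As far as these compounds go, whether an acetyl group, a methyl group or a pyridine ring on this nitrogen would move the number beyond the scatter remains open.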